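The source may report more compounds than this note shows. Statements on the series, on what has been measured and on what is new or still open speak of the compounds shown alone.

Within the data shown here, compound 2 `CCCCCCCCN(C)C(=O)Cn1cc(Cc2cnc(=O)n(CC(=O)N3CCN(C)CC3)c2)c(=O)nc1SCc1ccc(F)cc1` stands highest of the two numbers so far in a functional assay on a cell-free system (plasma, Oryctolagus cuniculus) for inhibition of platelet-activating factor acetylhydrolase (Homo sapiens), tested at 100 nM (on this read-out higher numbers stand for more inhibition at the one concentration tested (going by the name of the read-out) and lower numbers for less inhibition), where compound 2 gives 40%. Its nearest neighbour, compound 1 `CCCCCCCCN(C)C(=O)Cn1cc(Cc2cnc(=O)n(CC(=O)NCCC)c2)c(=O)nc1SCc1ccc(F)cc1`, gives 16% in this assay. Among the measured compounds shown here, the one step available, a number 24 percentage points higher from compound 1 to compound 2 (beyond the scatter), is the swap of 4-methylpiperazin-1-yl for propylamino on the carbonyl carbon, and it lies beyond the scatter.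

Compound 3 `CCCCCCCCN(C)C(=O)Cn1cc(Cc2cnc(=O)n(CC(=O)N3CCN(C(C)=O)CC3)c2)c(=O)nc1SCc1ccc(F)cc1` is the next member to be measured in this assay. It differs from compound 2 by acetyl in place of methyl on an amine nitrogen in a ring. For the measured compounds named here, no measured step alters this ring nitrogen, so the only guide is that the group on this carbonyl has mattered once, in the step from compound 1 to compound 2. A change of modest size is therefore expected, most likely downward toward the range of compound 1, though a step within the scatter cannot be ruled out. For compound 3 the expected value in this assay is 28%, within 8% to 50%, meaning an estimated step of a number 12 percentage points lower from compound 2 to compound 3 (beyond the scatter).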

Compound 3, a percentage reported as inhibition, at one concentration (the size of the read-out at that concentration, not a potency): 49%
The estimate for compound 3 lay 21 percentage points below the measured number; the measured number falls inside the stated range.
By their numbers in this assay, from the lowest: compound 1; then compounds 2 and 3 (each within the scatter of the next).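

On the amine nitrogen in the ring, acetyl in place of methyl gives a number 9 percentage points higher from compound 2 to compound 3 (within the scatter) in this assay, so the two groups cannot be told apart on this read-out. On the carbonyl carbon, 4-acetylpiperazin-1-yl in place of propylamino gives a number 33 percentage points higher from compound 1 to compound 3 (beyond the scatter), so among these three compounds, both ring-bearing amides stand clear of the propylamino amide, with none going against this. Nothing available here explains why methyl and acetyl read alike.

Open, going by these compounds, is whether a bare hydrogen, a longer acyl chain such as butanoyl, or a methanesulfonyl group on this ring nitrogen also reads like methyl and acetyl. Also open, on these data alone, is whether morpholin-4-yl on the carbonyl carbon holds the level of the two ring-bearing amides.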